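A few compounds are considered here, and "the series" means these few. Any claim that something is new, unique, unknown or untested is made for them only; others in the source may bear on it.

In a functional assay on HeLa cells (Homo sapiens) for cytotoxicity, read by MTT assay, with a stated time of 2 days (a higher number here means a weaker inhibitor, a lower number a stronger inhibitor), compound 1 `CN(C)c1ccc2nc(-c3cccc4ccccc34)[nH]c(=O)c2c1` gives 50 nM and compound 3 `CCN(CC)c1ccc2nc(-c3ccccc3C(F)(F)F)[nH]c(=O)c2c1` gives 100 nM. Compound 2 `Cc1cccc(-c2nc3ccc(C)cc3c(=O)[nH]2)c1` gives > 50000 nM, which is a limit of the assay and not a number. Compound 2 is the only one of the three without a measured number: the limit of > 50000 nM in this assay, at which 1 of the 3 values shown sits.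

Compound 4 `Cc1ccc2nc(-c3cccc(C(F)(F)F)c3)[nH]c(=O)c2c1` follows from compound 2 by one change, trifluoromethyl in place of methyl on an aromatic carbon. Among the measured compounds shown here, no measured pair shows this change on its own. Compound 3 also carries a trifluoromethyl group and gives 100 nM, but it has a diethylamino group on the core that compound 4 lacks, so it says little about this single change. In this assay, a modest shift toward a stronger inhibitor is therefore expected, or none that can be measured, and the estimated move is an at least 2.5-fold lower number from compound 2 to compound 4 (0.39 log units; beyond the scatter). For compound 4 the estimated value is 20000 nM, with an expected range of 2000 nM to 50000 nM.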

Compound 4, half-maximal inhibitory concentration: > 50000 nM
Compound 4: no number, only a limit; the forecaster's own chance of this, stated with the estimate: 50%; middle value at least 2.5-fold (0.39 log units) away from the limit.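

Compound 4 gives > 50000 nM, a limit of the assay and not a number. No step can be read between compound 2 and compound 4, because both stand at one limit in this assay: the limit of > 50000 nM in this assay, at which 2 of the 4 values shown sit.

The compounds shown leave open whether trifluoromethyl in place of methyl on an aromatic carbon changes the value at all.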